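The source may report more compounds than this note shows. Statements on the series, on what has been measured and on what is new or still open speak of the compounds shown alone.

Of the compounds shown here, three of a shared core have been measured in a functional assay on the whole organism (strain Wistar albino) for inhibition, with Rattus norvegicus as the target, read by paw edema, with stated times of 1 h and 4 h, at a dose of 40 mg/kg by the oral route; on this read-out higher numbers stand for more inhibition at the one dose given (going by the name of the read-out) and lower numbers for less inhibition. Compound 1 `Cc1nc(Cc2ccc(Cl)cc2)sc1C1SCC(=O)N1c1ccc(F)c(Cl)c1` gives 68.9%, compound 2 `Cc1ccc(N2C(=O)CSC2c2sc(Cc3ccc(Cl)cc3)nc2C)cc1` gives 81.3%, and compound 3 `COc1ccc(N2C(=O)CSC2c2sc(Cc3ccc(Cl)cc3)nc2C)cc1` gives 55.9%. Compound 3 stands lowest of the three: the step of a number 13 percentage points lower from compound 1 to compound 3 (beyond the scatter) and the step of a number 25.4 percentage points lower from compound 2 to compound 3 (beyond the scatter) both lie beyond the scatter, so the 4-methoxyphenyl on the amide-type nitrogen of compound 3 goes with the smallest inhibition seen here.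

Compound 4 `COc1ccc(N2C(=O)CSC2c2sc(-c3ccc(Cl)cc3)nc2C)cc1` differs from compound 3 at another place: 4-chlorophenyl in place of 4-chlorobenzyl on an aromatic carbon. Among the measured compounds shown here, none of the measured steps bears on this change, since every one of them swapped the ring on the amide-type nitrogen and left the 4-chlorobenzyl on the five-membered ring untouched. There is therefore no measured basis for a direction, and the expected step of a number 0.1 percentage points higher from compound 3 to compound 4 (within the scatter) is one within the scatter. Compound 4 is accordingly estimated at 56% in this assay, with a range from 40% to 72%.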

Compound 4, a percentage reported as inhibition, in the whole organism at one dose (the size of the read-out at that dose, not a potency): 59.1%
For compound 4 the middle estimate is 3.1 percentage points below the measured one; low and high end bracket the measured number.
By their numbers in this assay, from the lowest: compounds 3, 4 and 1 (each within the scatter of the next, the first and the last beyond it); then compound 2.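

The earlier steps shown here all swapped the ring on the amide-type nitrogen, whereas this one changes the aromatic carbon next to the ring nitrogen and next to the ring sulfur. Putting 4-chlorophenyl in place of 4-chlorobenzyl there gives a number 3.2 percentage points higher from compound 3 to compound 4 (within the scatter), so with the 4-methoxyphenyl kept on the nitrogen, this assay does not tell these two groups apart. No measurement of any other kind is at hand to explain this result.

From the compounds shown here alone, it stays open whether the same swap would also leave the number unmoved with the 4-methylphenyl of compound 2 on the nitrogen, where inhibition is highest. Going by these compounds, it is also open how this position would respond to a group of another type, such as a carboxylic acid, an amine or a longer chain carrying the 4-chlorophenyl.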